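Configuration-only change and tolerance on human fibroblasts

The compounds below may be only part of what the source reports. "The series", "measured", "known", "first", "only" and "open" are said of these compounds alone.

Compound 2 `Nc1nc2c(ncn2/C=C2/C[C@H]2[C@@H](O)CO)c(=O)[nH]1` is one of three compounds tested in an ADME assay on HFF cells (Homo sapiens) for cytotoxicity, read by neutral red uptake; a higher number here means that more compound is tolerated, a lower number that less compound is tolerated. Compound 2 gives 299000 nM, the highest of the two numbers actually measured. Compound 3 `Nc1ncnc2c1ncn2/C=C1/C[C@H]1[C@H](O)CO` gives 206000 nM, a value that lies within the scatter of that of compound 2. Compound 1 `Nc1ncnc2c1ncn2/C=C1\C[C@@H]1[C@H](O)CO` reaches only a limit of this assay, > 300000 nM. Compound 4 `Nc1nc2c(ncn2/C=C2/C[C@@H]2[C@H](O)CO)c(=O)[nH]1` has not yet been measured.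

the two compounds have the same atoms and bonds and differ only in configuration as drawn: 2 of 3 stereo elements differ; a stereocentre at a saturated ring carbon is drawn R in compound 2 and S in compound 4; a stereocentre at a saturated chain carbon is drawn R in compound 2 and S in compound 4

Only one measured step bears on a change of this kind: an at least 1.4-fold lower number from compound 1 to compound 3 (0.16 log units; that floor lies within the scatter), a pair that likewise differs in nothing but configuration, as shown by the fact that compounds 1 and 3 differ only in the configuration as drawn. That step stayed within the scatter. The step expected here is therefore a 1.2-fold lower number from compound 2 to compound 4 (0.08 log units; within the scatter), again no larger than the scatter. Compound 4 is estimated at 250000 nM, with a range from 120000 nM to 500000 nM. A result reported only as a limit remains possible, since the limit of > 300000 nM in this assay, at which 1 of the 3 values shown sits, shows that one of the three values already sits there.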

Compound 4, half-maximal cytotoxic concentration: > 300000 nM
Compound 4 was reported as a limit; the forecaster's own chance of this, stated with the estimate: 35%; middle value at least 1.2-fold (0.07 log units) away from the limit.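

This result adds a second compound at the limit of this assay: compound 4 reaches the limit > 300000 nM. Inverting the saturated ring carbon and the saturated chain carbon together gives a number no lower from compound 2 to compound 4 (the limit leaves the size open), so on the core of compound 2 this change of configuration brings no loss of tolerance that can be seen, a point the earlier step, which changed the ring carbon and the double bond on a different core, could not show. The comparison speaks to configuration alone: the fact that compounds 2 and 4 differ only in the configuration as drawn

Going by these compounds, the true size of this step stays open, including whether it lies within the scatter. The compounds shown also leave open whether tolerance would hold if a hydroxyl group gave way to a carboxylic acid or an amine.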